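This account rests on a few compounds, and the source may have more. Where it says the series, first, only, none or still open, it means among the compounds named here.

Measured so far: compound 1 `CCCn1c(=O)[nH]c2nc(-c3ccc(S(=O)(=O)N4CCN(Cc5cccc(C)c5)CC4)cc3)[nH]c2c1=O` gives 0.397 nM in an assay on CHO cells for displacement of a labelled ligand from adenosine receptor A2b (Homo sapiens), read by scintillation counting, with a stated time of 75 min, in the presence of a further agent that is not named here; a lower number here means a stronger inhibitor, a higher number a weaker inhibitor; compound 2 `CCCn1c(=O)[nH]c2nc(-c3ccc(S(=O)(=O)N4CCN(c5ccccc5Br)CC4)cc3)[nH]c2c1=O` gives 0.137 nM.

For the measured compounds named here, compound 2 has the lower of these two numbers, and the only measured step, a 2.9-fold lower number from compound 1 to compound 2 (0.46 log units; beyond the scatter), separates it from compound 1. Compound 3 `CCCn1c(=O)[nH]c2nc(-c3ccc(S(=O)(=O)N4CCN(Cc5ccc(Br)c(F)c5)CC4)cc3)[nH]c2c1=O` differs from compound 2 by 4-bromo-3-fluorobenzyl in place of 2-bromophenyl on an amine nitrogen in a ring. This returns a substituted benzyl to the ring nitrogen, as in compound 1, so the step of a 2.9-fold lower number from compound 1 to compound 2 (0.46 log units; beyond the scatter) is the one that bears here and is expected to be partly undone, giving a rise of about a 2.6-fold higher number from compound 2 to compound 3 (0.41 log units; beyond the scatter). Compound 3 is therefore estimated at 0.35 nM, within the range 0.12 nM to 1 nM.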

Compound 3, inhibition constant: 0.473 nM
Compound 3: middle estimate off by 1.4-fold (0.13 log units), on the low side, within the range that was stated.
By their numbers in this assay, from the lowest: compound 2; then compounds 1 and 3 (each within the scatter of the next).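

In this assay, 4-bromo-3-fluorobenzyl in place of 2-bromophenyl on the ring nitrogen gives a 3.5-fold higher number from compound 2 to compound 3 (0.54 log units; beyond the scatter) and so a weaker inhibitor. Against 3-methylbenzyl, the same group gives a 1.2-fold higher number from compound 1 to compound 3 (0.08 log units; within the scatter) and so these two differently substituted benzyl groups cannot be told apart here. Both benzyl compounds therefore stand weaker than compound 2, but nothing available explains why. Still open, as far as these compounds go, is whether a benzyl group carrying an amine or a carboxylic acid would behave the same way. A longer chain between the ring nitrogen and the benzene ring also remains untested in what is shown.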